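This account rests on a few compounds, and the source may have more. Where it says the series, first, only, none or still open, it means among the compounds named here.

Measured so far in a functional assay on HEL cells (Homo sapiens); a lower number here means that less compound is tolerated, a higher number that more compound is tolerated:

Compound 1 `Cc1cn([C@@H]2O[C@H](CO[Si](C)(C)C(C)(C)C)[C@@]3(OS(=O)(=O)C=C3NCC(=O)O)[C@H]2O[Si](C)(C)C(C)(C)C)c(=O)n(C)c1=O` gives 136000 nM.
Compound 2 `Cc1cn([C@@H]2O[C@@H]3COC(=O)[C@]3(OS(C)(=O)=O)[C@H]2O)c(=O)[nH]c1=O` gives only a limit of the assay, >= 36000 nM.
Compound 3 `Cc1cn([C@@H]2O[C@H](CO[Si](C)(C)C(C)(C)C)[C@@]3(OS(=O)(=O)C=C3NC(N)=O)[C@H]2O[Si](C)(C)C(C)(C)C)c(=O)n(C)c1=O` gives 11000 nM.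

Within the data shown here, of the two actual numbers, compound 3 stands lowest, with compound 1 as its only neighbour; the single measured change between them is a 12-fold lower number from compound 1 to compound 3 (1.09 log units; beyond the scatter), a large step.

Compound 4 `Cc1cn([C@@H]2O[C@H](CO[Si](C)(C)C(C)(C)C)[C@@]3(OS(=O)(=O)C=C3NCCC(=O)O)[C@H]2O[Si](C)(C)C(C)(C)C)c(=O)n(C)c1=O` differs from compound 3 by 2-carboxyethyl in place of carbamoyl on an amine nitrogen. This runs the measured step backwards, from carbamoyl toward an acid-bearing chain, and the 2-carboxyethyl chain is a close relative of the carboxymethyl of compound 1. A rise of roughly the same size is therefore expected.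

Compound 4 is expected to give 100000 nM, somewhere between 30000 nM and 300000 nM. The expected step is a 9.1-fold higher number from compound 3 to compound 4 (0.96 log units; beyond the scatter).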

Compound 4, half-maximal cytotoxic concentration: 34000 nM
For compound 4 the middle estimate is 2.9-fold (0.47 log units) above the measured one; the range from low to high includes it.
By their numbers in this assay, from the lowest: compound 3; then compound 4; then compound 1.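

In this assay, 2-carboxyethyl in place of carbamoyl on this amine nitrogen gives a 3.1-fold higher number from compound 3 to compound 4 (0.49 log units; beyond the scatter), so a second acid-bearing chain also tolerates more compound than the carbamoyl of compound 3. Chain length counts as well: adding one carbon to the chain gives a 4.0-fold lower number from compound 1 to compound 4 (0.60 log units; beyond the scatter), so the acid group alone does not set the number. Nothing shown explains either step.

Open, going by these compounds, is whether a longer chain, such as 3-carboxypropyl, continues this fall. Also open, on these data alone, is whether a methyl ester or a plain propyl chain behaves like the acids.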